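A few compounds are considered here, and "the series" means these few. Any claim that something is new, unique, unknown or untested is made for them only; others in the source may bear on it.

In a functional assay on the whole organism (strain Sprague-Dawley) for inhibition, with Rattus norvegicus as the target, with a stated time of 10 min (on this read-out lower numbers stand for an effect already at smaller amounts and higher numbers for an effect only at larger amounts of compound), compound 1 `O=C(O)c1cnc(-c2ccccc2[N+](=O)[O-])[nH]c1=O` gives only a limit, > 50 mg/kg. Compound 2 `CCOc1ccc(S(N)(=O)=O)cc1-c1ncc(C(=O)O)c(=O)[nH]1` also gives only a limit, > 50 mg/kg. From the compounds shown here alone, compound 3 `CCOC(=O)c1cnc(-c2ccccc2[N+](=O)[O-])[nH]c1=O` has no number of its own, its entry reading "not determined" (no result reported), so its place on the dose scale is unknown. The nearest reference is the limit of > 50 mg/kg in this assay, at which 2 of the 3 values shown sit. Compound 4 `CCOC(=O)c1cnc(-c2ccccc2OCC(C)C)[nH]c1=O` has not yet been measured. The change is isobutoxy in place of nitro on an aromatic carbon, with isobutoxy in place of nitro on an aromatic carbon. Among the compounds with values here, no measured pair shows this exchange, so only a moderate step towards smaller doses is expected in this assay, and a result at the same limit remains possible. For compound 4, the expected dose is an estimated 15 mg/kg, within a range of 3 mg/kg to 50 mg/kg.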

Compound 4, dose for 50% inhibition: 3 mg/kg
For compound 4 the middle estimate is 5.0-fold (0.70 log units) above the measured one; the measured number falls inside the stated range.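

Compound 3 carries no number in this assay, so the step to compound 4, at 3 mg/kg, cannot be read. The compounds shown leave open how much isobutoxy in place of nitro itself changes the dose.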